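Extending the chain on compound 3 in a cytotoxicity screen

A few compounds are considered here, and "the series" means these few. Any claim that something is new, unique, unknown or untested is made for them only; others in the source may bear on it.

The series gathers three measured compounds and one awaiting measurement. Compound 1 `CCCCCCc1ccc(-c2ccc(C(=O)N[C@@H](CCCN)C(=O)N[C@H](C(=O)N[C@@H](C)C(=O)N[C@@H](CC(N)=O)C(=O)N[C@@H](C)B3OC4C[C@@H]5C[C@@H](C5(C)C)[C@]4(C)O3)[C@@H](C)O)cc2)cc1`, compound 2 `CCCCCCc1ccc(-c2c[nH]c3ccc(C(=O)N[C@@H](CCCN)C(=O)N[C@H](C(=O)N[C@@H](C)C(=O)N[C@H]4Cc5cn(nn5)CCO[C@@H]5C[C@@H]6OB(O[C@@H]6C5)[C@H](C)NC4=O)[C@@H](C)O)cc23)cc1` and compound 3 `CCCCc1ccc(-c2ccc(C(=O)N[C@@H](CCCN)C(=O)N[C@H](C(=O)N[C@@H](C)C(=O)N[C@H]3Cc4cn(nn4)CCCN4C[C@@H]5OB(O[C@@H]5C4)[C@H](C)NC3=O)[C@@H](C)O)cc2)cc1` were tested in an ADME assay on HepG2 cells (Homo sapiens) for cytotoxicity, with a stated time of 72 h; on this read-out higher numbers stand for weaker inhibition and lower numbers for stronger inhibition. Compound 1 gives 11700 nM, compound 2 gives 23700 nM, and compound 3 gives 29100 nM. Compound 3 stands at the highest of the three numbers; the gap to compound 2 is within the scatter, while the gap to compound 1 is beyond it, so compound 3 sits above compound 1 on this read-out, with compound 2 not separated from either by a firm margin.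

Compound 4 `CCCCCCc1ccc(-c2ccc(C(=O)N[C@@H](CCCN)C(=O)N[C@H](C(=O)N[C@@H](C)C(=O)N[C@H]3Cc4cn(nn4)CCCN4C[C@@H]5OB(O[C@@H]5C4)[C@H](C)NC3=O)[C@@H](C)O)cc2)cc1` arises from compound 3 by a single change: ethyl in place of hydrogen on a saturated chain carbon, four bonds along the chain from an aromatic carbon. Among the compounds with values here, none of the three measured pairs repeats this step on its own, so no measured pair speaks to it directly; the only bearing is that compound 1 and compound 2 carry the longer chain yet differ from compound 3 in other parts as well.

He expects the step from compound 3 to compound 4 in this assay to be a 1.5-fold lower number from compound 3 to compound 4 (0.19 log units; within the scatter), toward somewhat stronger inhibition but within or close to the scatter. Compound 4 is therefore estimated at 19000 nM in this assay, with a range from 8500 nM to 42000 nM.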

Compound 4, half-maximal inhibitory concentration: 4000 nM
For compound 4 the middle estimate is 4.8-fold (0.68 log units) above the measured one, and the stated range ends above it.
By their numbers in this assay, from the lowest: compound 4; then compound 1; then compounds 2 and 3 (each within the scatter of the next).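

In this assay, ethyl in place of hydrogen on a saturated chain carbon, four bonds along the chain from an aromatic carbon, gives a 7.3-fold lower number from compound 3 to compound 4 (0.86 log units; beyond the scatter) and so moves the read-out toward stronger inhibition by a margin beyond the usual scatter. Within the data shown here, this is the first pair that differs in this one place, and it shows that this chain position alone can shift the cytotoxicity read-out, something the earlier compounds could not show, since they also differ from one another in other parts of their structures. Nothing measured here accounts for the size of this step, so the result stands as an observation from a single pair.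

The compounds shown leave open whether a methyl at this carbon would give part of the shift, and whether a longer chain would extend it or reverse it. They also leave open how a hydroxyl or an amine at the end of the chain would compare with ethyl, and whether the same change would have a similar effect on a different core.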